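The source may hold more compounds than are shown below. What is called first, only, known or untested is meant among the compounds shown, and "the series" means these compounds.

Compound 2 `COc1cc(Cl)cc(-c2nn(-c3cccc(NC(=O)Nc4ccc(Cl)c(C(F)(F)F)c4)c3)cc2-c2ccncc2)c1` gives 98% in a functional assay on SW-620 cells (Homo sapiens) for inhibition, read by sulforhodamine B assay, with a stated time of 48 h, tested at 0.01 uM (on this read-out higher numbers stand for a weaker effect at the one concentration tested and lower numbers for a stronger effect), level at the digits shown with compound 3 `COc1cc(Cl)cc(-c2nn(-c3cccc(NC(=O)Nc4cc(C(F)(F)F)cc(C(F)(F)F)c4)c3)cc2-c2ccncc2)c1`, which gives 98%, and within the scatter of compound 1 `O=C(Nc1cccc(-n2cc(-c3ccncc3)c(-c3cc(O)cc(Cl)c3)n2)c1)Nc1ccc(Cl)c(C(F)(F)F)c1`, which gives 97%. All three sit at the weak end of the scale at the single concentration tested. Within the data shown here, the only one-place step measured, a number 1 percentage points higher from compound 1 to compound 2 (within the scatter), concerns a methyl in place of hydrogen on an oxygen on an aromatic ring and stays within the scatter. Compound 4 `COc1cc(Cl)cc(-c2nn(-c3cccc(NC(=O)c4cccc(C(F)(F)F)c4)c3)cc2-c2ccncc2)c1` differs from compound 2 by 3-(trifluoromethyl)phenyl in place of (4-chloro-3-(trifluoromethyl)phenyl)amino on a carbonyl carbon. Among the measured compounds shown here, no measured step touches the carbonyl carbon, so nothing here bears directly on this change. With every measured compound near the top of the scale, compound 4 is expected to remain there, the step of a number 2 percentage points lower from compound 2 to compound 4 (within the scatter) not reaching beyond the scatter. Compound 4 is therefore estimated at 96%, within 85% to 104%.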

Compound 4, a percentage reported as activity, at one concentration (the size of the read-out at that concentration, not a potency): 101%
Beside the measured number, compound 4's estimate is 5 percentage points below it, within the range that was stated.
By their numbers in this assay, from the lowest: compounds 1, 2, 3 and 4 (each within the scatter of the next).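

In this assay, among these compounds, the change gives a number 3 percentage points higher from compound 2 to compound 4 (within the scatter), the first measured step at this carbonyl carbon. The (4-chloro-3-(trifluoromethyl)phenyl)amino group, with its nitrogen and chlorine, thus gives way to 3-(trifluoromethyl)phenyl with no shift beyond the scatter, and compound 4 stays at the weak end of the scale. Nothing available explains this result. Going by these compounds, whether the nitrogen and the chlorine would count separately remains open. So does whether a different group on this carbonyl carbon, such as a morpholine or a carboxylic acid-bearing phenyl, would move the read-out beyond the scatter.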